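Removing One Methoxy Group: From Compound 2 to Compound 4

The source may hold more compounds than are shown below. What is called first, only, known or untested is meant among the compounds shown, and "the series" means these compounds.

Among the measured compounds shown here, compound 2 `COc1cc(-c2cc(/C=C/C(=O)c3ccc(N)cc3)[nH]n2)cc(OC)c1OC` is one of three compounds measured so far. In a functional assay on Malme-3M cells (Homo sapiens) for cytotoxicity, read by sulforhodamine B assay, with a stated time of 48 h, tested at 0.01 uM (a higher number here means a weaker effect of the compound at the concentration tested, a lower number a stronger effect), compound 2 gives 98%, the highest of the three numbers, though its neighbours sit close by. Compound 3 `COc1ccc(C(=O)/C=C/c2cc(-c3cc(OC)c(OC)c(OC)c3)n[nH]2)cc1OC` gives 95%, and compound 1 `COc1ccc(-c2cc(/C=C/C(=O)c3ccc(N)cc3)[nH]n2)cc1` gives 93%; both differ from compound 2 only within the scatter. For the measured compounds named here, the single step followed between measured compounds, a number 3 percentage points lower from compound 2 to compound 3 (within the scatter), replaced a group on the carbonyl carbon and stayed within the scatter.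

Compound 4 `COc1ccc(-c2cc(/C=C/C(=O)c3ccc(N)cc3)[nH]n2)cc1OC` has not yet been measured. Its change from compound 2 is hydrogen in place of methoxy on an aromatic carbon. Going by the values given here, no measured step alters this ring in the same way; the only step known, a number 3 percentage points lower from compound 2 to compound 3 (within the scatter), concerns another part of the molecule and was within the scatter. With all three measured numbers so close, no step beyond the scatter is expected here either. Compound 4 is therefore estimated to give 95%, with a range from 85% to 102%. The expected step of a number 3 percentage points lower from compound 2 to compound 4 (within the scatter) is estimated to lie within the scatter.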

Compound 4, a percentage reported as activity, at one concentration (the size of the read-out at that concentration, not a potency): 104%
Estimate against measurement, compound 4: 9 percentage points below; the measured number lies above the stated range.
By their numbers in this assay, from the lowest: compounds 1, 3, 2 and 4 (each within the scatter of the next, the first and the last beyond it).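

In this assay, taking the methoxy group off this ring gives a number 6 percentage points higher from compound 2 to compound 4 (within the scatter), so removing it from a carbon ortho to a methoxy group is not distinguishable from leaving it in place. Among the compounds shown here, the reverse kind of change, seen at a different carbon of that ring, gives a number 11 percentage points higher from compound 1 to compound 4 (beyond the scatter), the first step to pass the scatter: here the added methoxy goes with a modestly weaker effect at the concentration tested. Nothing measured here explains either step, and the two cannot be tied to a cause.

What the compounds shown leave open is how a different group on this aromatic carbon, such as a hydroxyl, a fluorine or an amine, would read. They also leave open whether the modest step would hold at any other concentration.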